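Swapping a bromophenyl for a pyridyl and tolerability

The compounds below may be only part of what the source reports. "The series", "measured", "known", "first", "only" and "open" are said of these compounds alone.

The series shares one core, seen in compound 1, `Cc1nc(-c2cccnc2)sc1-c1nnc(-c2ccc(Br)cc2)o1`, and compound 2, `Cc1nc(-c2cccnc2)sc1-c1nnc(-c2ccccc2Cl)o1`. In an ADME assay on THP-1 cells (Homo sapiens) for cytotoxicity, read by MTT assay (a higher number here means that more compound is tolerated, a lower number that less compound is tolerated), compound 1 gives > 100 ug/mL, which is a limit of the assay rather than a number. In this assay compound 2 likewise gives > 100 ug/mL, again a limit and not a number. For the measured compounds named here, the one measured step, a step that the two limits leave unreadable from compound 1 to compound 2, therefore cannot be sized, since (the limit of > 100 ug/mL in this assay, at which 2 of the 2 values shown sit).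

Compound 3, `Cc1nc(-c2cccnc2)sc1-c1nnc(-c2ccncc2)o1`, is not yet measured. It differs from compound 1 in this way: pyridin-4-yl in place of 4-bromophenyl on an aromatic carbon.

Going by the values given here, only the step from compound 1 to compound 2 could bear on this change, and it is unreadable; two values at a limit give no direction and no size. Nothing in the measured data therefore points to a step beyond the scatter in this assay, in either direction. The step expected from that is a step that the limit leaves unreadable from compound 1 to compound 3. In this assay compound 3 is estimated at 150 ug/mL, with a likely range from 60 ug/mL to 400 ug/mL, and most probably the assay will again report only a limit.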

Compound 3, half-maximal cytotoxic concentration: > 100 ug/mL
Compound 3: a limit, no number; the forecaster's own chance of this, stated with the estimate: 80%; the middle value lies beyond the limit too.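

For the compounds shown here, compound 3 adds no step that can be read: its comparisons with compound 1 and compound 2 cannot be sized, because all three compounds give a limit and not a number: the limit of > 100 ug/mL in this assay, at which 3 of the 3 values shown sit. The compounds shown leave open how much of each is tolerated in this assay and whether 4-bromophenyl, 2-chlorophenyl and pyridin-4-yl differ there at all.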